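The source may hold more compounds than are shown below. What is called first, only, known or untested is meant among the compounds shown, and "the series" means these compounds.

Measured compounds:
- compound 1, `COc1ccc(-c2cc(/C=C/C(=O)c3ccc(N)cc3)[nH]n2)cc1`: 65%
- compound 2, `COc1cc(-c2cc(/C=C/C(=O)c3ccc(N)cc3)[nH]n2)cc(OC)c1OC`: 76%

Both were tested in a functional assay on U-251 cells (Homo sapiens) for cytotoxicity, read by sulforhodamine B assay, with a stated time of 48 h, tested at 1 uM; a lower number here means a stronger effect, a higher number a weaker effect of the compound at the concentration tested. Compound 2 gives 76% there, the higher of the two numbers, which means the weaker effect. Going by the values given here, its only neighbour is compound 1, with 65%, a number lower by a margin beyond the usual scatter, so compound 1 shows the stronger effect of the pair.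

Compound 3, `COc1ccc(-c2cc(/C=C/C(=O)c3ccc(N)cc3)[nH]n2)cc1OC`, has not yet been measured in this assay. Relative to compound 2 the change is hydrogen in place of methoxy on an aromatic carbon. The step takes compound 3 part of the way from compound 2 toward compound 1 in structure, so a small drop in the number, perhaps no larger than the scatter, is expected; the step of a number 6 percentage points lower from compound 2 to compound 3 (within the scatter) is the estimated size. Compound 3 is expected to give about 70%, within a range of 57% to 83%.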

Compound 3, a percentage reported as activity, at one concentration (the size of the read-out at that concentration, not a potency): 88%
For compound 3 the middle estimate is 18 percentage points below the measured one, outside the stated range (above it).
By their numbers in this assay, from the lowest: compound 1; then compound 2; then compound 3.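

In this assay, putting hydrogen in place of the methoxy group that sits ortho to a methoxy group gives a number 12 percentage points higher from compound 2 to compound 3 (beyond the scatter), so at this position the methoxy group goes with the stronger effect. The opposite swap, methoxy in place of hydrogen on an aromatic carbon, gives a number 23 percentage points higher from compound 1 to compound 3 (beyond the scatter), so here the added methoxy group goes with the weaker effect. The same kind of swap therefore moves the number in opposite directions in these two steps, and compound 3 shows the weakest effect of the three.

The data shown offer no explanation for this reversal. On these data alone, it also remains open whether a hydroxy group, an ethoxy group or a fluorine atom on this aromatic carbon would behave like methoxy or like hydrogen.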